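A few compounds are considered here, and "the series" means these few. Any claim that something is new, unique, unknown or untested is made for them only; others in the source may bear on it.

In a functional assay on CHO-K1 cells for antagonist activity at Urotensin-2 receptor (Rattus norvegicus), read by FLIPR and calcium flux, with a stated time of 1 h (a lower number here means a stronger inhibitor, a higher number a weaker inhibitor), compound 2 `COc1ccc([C@@H](CCCN(C)S(=O)(=O)c2cccs2)N2Cc3c(cccc3N3CCN(C4CC4)CC3)C2=O)cc1OC` gives 13 nM. For the measured compounds named here, the only other measured compound, compound 1 `CCN1CCN(c2cccc3c2CN([C@H](CCCNS(=O)(=O)c2c[nH]cn2)c2ccc(OC)c(OC)c2)C3=O)CC1`, gives in this assay 23 nM; the two numbers lie within the usual scatter of each other, so nothing separates them. Compound 3 `COc1ccc([C@@H](CCCN(C)S(=O)(=O)c2cccs2)N2Cc3c(cccc3N3CCNCC3)C2=O)cc1OC` has not yet been measured in this assay. It differs from compound 2 by hydrogen in place of cyclopropyl on an amine nitrogen in a ring. Going by the values given here, no step between measured compounds covers such a change, so the expectation rests on the structural change alone: a modest weakening is expected, estimated as a 2.3-fold higher number from compound 2 to compound 3 (0.36 log units; beyond the scatter), possibly none beyond the scatter. Compound 3 is estimated at 30 nM, with a range from 8 nM to 120 nM.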

Compound 3, half-maximal inhibitory concentration: 39 nM
Compound 3: middle estimate off by 1.3-fold (0.11 log units), on the low side, within the range that was stated.
By their numbers in this assay, from the lowest: compounds 2, 1 and 3 (each within the scatter of the next, the first and the last beyond it).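

Going from 4-cyclopropylpiperazin-1-yl to piperazin-1-yl gives in this assay a 3.0-fold higher number from compound 2 to compound 3 (0.48 log units; beyond the scatter), the first single-place step available here, and it shows that the group on this amine nitrogen in a ring affects the number. The effect is modest: with hydrogen on that nitrogen, compound 3 still gives 39 nM, so the cyclopropyl is not required for inhibition. Nothing available explains this step.

Still open, on these data alone, is how a methyl, an isopropyl or an acetyl on this nitrogen would compare. Compound 1 carries an ethyl there but also differs elsewhere, so it cannot settle this.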